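Chain extension on the sulfonyl side: lipophilicity notes

The compounds below may be only part of what the source reports. "The series", "measured", "known", "first", "only" and "open" are said of these compounds alone.

Measured so far in a physicochemical assay for lipophilicity; a higher number here means a more lipophilic compound, a lower number a more polar compound:
compound 1, `CCCCCCS(=O)(=O)c1ccc(O)c(C(=O)Nc2ccc(Br)cc2)c1`: 5.2
compound 2, `CCCCCCCCS(=O)(=O)c1ccc(O)c(C(=O)Nc2ccc(C(F)(F)F)cc2)c1`: 6.3
compound 3, `CCCCCCCCCCS(=O)(=O)c1ccc(O)c(C(=O)Nc2ccc(Br)cc2)c1`: 7.36

Compound 3 stands highest of the three numbers; compound 2 comes nearest and compound 1 lies furthest below, both gaps beyond the scatter. Compound 2 differs from compound 3 in more than one place, so its value is noted only as it stands.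

Compound 4, `CCCCCCCCCCCCS(=O)(=O)c1ccc(O)c(C(=O)Nc2ccc(Br)cc2)c1`, has not yet been measured. Its difference from compound 3: ethyl in place of hydrogen on a saturated chain carbon, ten or more bonds along the chain from a sulfonyl sulfur. Among the measured compounds shown here, one measured step bears on this: a number 2.16 log units higher from compound 1 to compound 3 (beyond the scatter). That step added four chain carbons; the present change adds two, further out along the same chain. A rise is therefore expected in this assay, beyond the scatter and upward, and its size is given by the expected step below.

The expected step is a number 1.04 log units higher from compound 3 to compound 4 (beyond the scatter). For compound 4 the estimate is 8.4, with a range from 7.9 to 8.9.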

Compound 4, partition coefficient: 8.44
For compound 4 the middle estimate is 0.04 log units below the measured one; low and high end bracket the measured number.
By their numbers in this assay, from the lowest: compound 1; then compound 2; then compound 3; then compound 4.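

In this assay, ethyl in place of hydrogen on a saturated chain carbon, ten or more bonds along the chain from a sulfonyl sulfur, still gives a number 1.08 log units higher from compound 3 to compound 4 (beyond the scatter), so the climb does not flatten at this chain length. Set against a number 2.16 log units higher from compound 1 to compound 3 (beyond the scatter), the rise per added chain carbon is unchanged, and the whole run amounts to a number 3.24 log units higher from compound 1 to compound 4 (beyond the scatter), with none of these three compounds going against the trend. No supporting data bear on why the number climbs in this way.

Going by these compounds, whether the same rise per carbon holds for a still longer chain remains open, since the trend rests on three compounds only. Also open, on these data alone, is how this assay would respond to a carboxylic acid or an amine at the end of the chain.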